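This account rests on a few compounds, and the source may have more. Where it says the series, first, only, none or still open, it means among the compounds named here.

In an ADME assay on Vero cells (Chlorocebus sabaeus) for cytotoxicity, read by neutral red uptake, with a stated time of 48 h (a higher number here means a weaker inhibitor, a lower number a stronger inhibitor), compound 3 `CN(C)c1nc(Cl)nc2c1ncn2CCCNc1ccnc2cc(Cl)ccc12` gives > 11400 nM as a limit of the assay, not a number. Compound 1 `Clc1ccc2c(NCCn3cnc4c(N5CCCC5)nc(Cl)nc43)ccnc2c1` gives > 11100 nM as a limit too. Compound 2 `CN1CCN(c2nc(Cl)nc3c2ncn3CCNc2ccnc3cc(Cl)ccc23)CC1` gives > 10400 nM as a limit as well. Compound 4 `CCN(CC)c1nc(Cl)nc2c1ncn2CCCNc1ccnc2cc(Cl)ccc12` carries diethylamino in place of dimethylamino on an aromatic carbon and has not yet been measured. Among the measured compounds shown here, the only measured step that bears on this change is a step that the two limits leave unreadable from compound 1 to compound 2 with 4-methylpiperazin-1-yl in place of pyrrolidin-1-yl on an aromatic carbon, so it offers no size to carry over. No step beyond the usual scatter is therefore expected in this assay for this change, in either direction. The estimated step is an at least 1.0-fold lower number from compound 3 to compound 4 (0.02 log units; that floor lies within the scatter) on these limited grounds. Compound 4 is estimated at 10700 nM with an expected range from 6000 nM to 16000 nM and may well return only a limit again.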

Compound 4, half-maximal inhibitory concentration: > 10700 nM
Compound 4 was reported as a limit (the forecaster's own chance of this, stated with the estimate: 80%); the middle value lies on the limit itself.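

Compound 3 and compound 4 each return only a limit in this assay, and the step between them cannot be read. From the compounds shown here alone, whether diethylamino in place of dimethylamino changes the true half-maximal concentration remains open.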